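Working notes: 4-methylphenyl to 4-methoxyphenyl in the series

The source may report more compounds than this note shows. Statements on the series, on what has been measured and on what is new or still open speak of the compounds shown alone.

Measured in a functional assay on A549 cells (Homo sapiens) for antiproliferative activity, read by MTT assay, with a stated time of 72 h; on this read-out lower numbers stand for stronger inhibition and higher numbers for weaker inhibition:
- compound 1 `CNc1nc(-c2cc(OC)c(OC)c(OC)c2)c(-c2ccc(OC)cc2)s1`: 138 nM
- compound 2 `COc1cc(-c2nc(N(C)C)sc2-c2ccc(C)cc2)cc(OC)c1OC`: 3960 nM

Of the two measured compounds, compound 2 has the higher number, at 3960 nM. Compound 1 lies lower at 138 nM, and that gap is beyond the scatter. The two compounds differ in more than one place, so the gap cannot be assigned to any single change.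

The next compound is compound 3 `COc1ccc(-c2sc(N(C)C)nc2-c2cc(OC)c(OC)c(OC)c2)cc1`, which has methoxy in place of methyl on an aromatic carbon, para to a large group: methoxy in place of methyl on an aromatic carbon. Among the compounds with values here, no measured pair in this assay isolates this change, so the expectation rests on thin evidence. Compound 1 also carries the 4-methoxyphenyl and gives 138 nM, which points to a lower number rather than a higher one. A moderate drop is expected, and one within the scatter remains possible. The estimated change is a 3.6-fold lower number from compound 2 to compound 3 (0.56 log units; beyond the scatter). For compound 3 the estimated value is 1100 nM, with an expected range of 200 nM to 5000 nM.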

Compound 3, half-maximal inhibitory concentration: > 10000 nM
Compound 3: no number, only a limit; the forecaster's own chance of this, stated with the estimate: 5%; middle value at least 9.0-fold (0.95 log units) away from the limit.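

In this assay, methoxy in place of methyl on an aromatic carbon, para to a large group, now reads in one place as an at least 2.5-fold higher number from compound 2 to compound 3 (0.40 log units; beyond the scatter), so with the dimethylated nitrogen kept, this change runs towards weaker inhibition, which compound 1 alone could not indicate. The same series also gives an at least 72-fold higher number from compound 1 to compound 3 (1.86 log units; beyond the scatter) for methyl in place of hydrogen on a nitrogen on an aromatic ring, so the 4-methoxyphenyl alone does not carry the low number of compound 1, and in this pair the single added methyl on the nitrogen separates strong inhibition from weak. Compound 3 stands as a limit of the assay and not a number, so each of these steps gives only a bound on its size: the limit of > 10000 nM in this assay, at which 1 of the 3 values shown sits.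

The compounds shown leave open how the 4-methylphenyl behaves when the nitrogen carries a single methyl, and so whether the two changes add up or depend on each other. Also open, going by these compounds, is how an ethoxy or a chlorine in the place of the methoxy, or an ethyl or a free amine hydrogen pair on the nitrogen, would read in this assay.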